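Nitro to Amino on a Compound at the Assay Limit

This account rests on a few compounds, and the source may have more. Where it says the series, first, only, none or still open, it means among the compounds named here.

Compound 1, `COC(=O)CC1c2ccccc2N=C(NCCCCCNC(=O)OC(C)(C)C)N1c1ccc(-c2ccccc2)cc1`: 3830 nM
Compound 2, `COC(=O)CC1c2ccccc2N=C(Nc2ccc(-c3ccccc3)cc2)N1CCCCCN`: 2900 nM
Compound 3, `CN(C)C1=Nc2ccccc2C(CC(=O)NCc2ccc([N+](=O)[O-])cc2)N1c1ccccc1`: > 100000 nM

Of the compounds shown here, three have been measured in a functional assay on A549 cells (Homo sapiens) for inhibition, read by sulforhodamine B assay, with a stated time of 72 h; on this read-out lower numbers stand for stronger inhibition of growth and higher numbers for weaker inhibition of growth. Compound 1 gives 3830 nM and compound 2 gives 2900 nM; these two values lie within the usual scatter of each other, so no order between them can be claimed. Compound 3 is of a different kind: in this assay compound 3 returns > 100000 nM, which is a limit of the assay and not a number. Compound 3 therefore sits at the limit of > 100000 nM in this assay, at which 1 of the 3 values shown sits, the weakest point on the scale shown.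

Compound 4, `CN(C)C1=Nc2ccccc2C(CC(=O)NCc2ccc(N)cc2)N1c1ccccc1`, has not yet been measured. It differs from compound 3 in a single place: amino in place of nitro on an aromatic carbon. Among the measured compounds shown here, no pair of measured compounds shares this change, so no measured step tells what size of shift such a swap brings in this assay. Starting from a compound that gives only a limit, the step of a number no higher from compound 3 to compound 4 (the limit leaves the size open) is expected to be none beyond the scatter, with a real chance that compound 4 again returns only a limit. Compound 4 is estimated at 100000 nM, with a range from 20000 nM to 300000 nM.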

Compound 4, concentration for 50% growth inhibition: > 100000 nM
Compound 4: only a limit was reported; the forecaster's own chance of this, stated with the estimate: 65%; the middle value lies on the limit itself.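

In this assay compound 4 gives > 100000 nM, which is a limit of the assay and not a number. Among the compounds shown here, compound 3 stands at a limit as well, so no step from compound 3 to compound 4 can be read. The compounds shown leave open what shift, if any, amino in place of nitro on an aromatic carbon brings in this assay.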